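Cyano for tert-butyl on the aryl ring of compound 2

This account rests on a few compounds, and the source may have more. Where it says the series, first, only, none or still open, it means among the compounds named here.

Measured compounds:
compound 1 `COc1cccc(OC)c1C(=O)Nc1nnc(-c2ccc(Cl)cc2)s1` — 58.9 nM
compound 2 `COc1cccc(OC)c1C(=O)Nc1nnc(-c2ccc(C(C)(C)C)cc2)s1` — 525 nM
compound 3 `COc1cccc(OC)c1C(=O)Nc1nnc(-c2ccc([N+](=O)[O-])cc2)s1` — 269 nM

Three amides sharing one core were tested in a functional assay on the whole organism (integument) for inhibition, with Chilo suppressalis as the target, read by scintillation counting, with a stated time of 72 h, in the presence of a further agent that is not named here; a lower number here means a stronger inhibitor, a higher number a weaker inhibitor. Compound 1 gives 58.9 nM, compound 3 gives 269 nM, and compound 2 gives 525 nM, the highest of the three numbers. Compound 2 sits nearest to compound 3, the gap being a 2.0-fold lower number from compound 2 to compound 3 (0.29 log units; within the scatter), and furthest from compound 1, the gap being an 8.9-fold higher number from compound 1 to compound 2 (0.95 log units; beyond the scatter).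

The unmeasured compound 4 `COc1cccc(OC)c1C(=O)Nc1nnc(-c2ccc(C#N)cc2)s1` differs from compound 2 in one place: cyano in place of tert-butyl on an aromatic carbon. Among the compounds with values here, two measured steps bear on this change. Replacing chloro with tert-butyl gave an 8.9-fold higher number from compound 1 to compound 2 (0.95 log units; beyond the scatter), while replacing tert-butyl with nitro gave a 2.0-fold lower number from compound 2 to compound 3 (0.29 log units; within the scatter). Both point the same way: leaving tert-butyl has given a lower number, once clearly and once within the scatter. Cyano, like nitro, is a small group carrying one hydrogen-bond acceptor, so a lower number than compound 2 is expected in this assay, of a size between those two steps.

For compound 4 the expected step is a 3.3-fold lower number from compound 2 to compound 4 (0.52 log units; beyond the scatter). Compound 4 is therefore estimated at 160 nM, with a range from 55 nM to 450 nM.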

Compound 4, half-maximal inhibitory concentration: 200 nM
Compound 4: the middle estimate sits 1.3-fold (0.10 log units) below what was measured; low and high end bracket the measured number.
By their numbers in this assay, from the lowest: compound 1; then compounds 4, 3 and 2 (each within the scatter of the next, the first and the last beyond it).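

In this assay, the change from tert-butyl to cyano gives a 2.6-fold lower number from compound 2 to compound 4 (0.42 log units; beyond the scatter), so compound 4 joins compound 1 as a second compound whose number stands clear of compound 2, whereas the nitro group of compound 3 did not. Cyano and nitro cannot be told apart at this position, with a 1.3-fold lower number from compound 3 to compound 4 (0.13 log units; within the scatter), and so the two groups sit together in a middle tier of the series. Chloro still holds the lowest number of the four, beyond the scatter from each of the others, and cyano in its place gives a 3.4-fold higher number from compound 1 to compound 4 (0.53 log units; beyond the scatter), which makes compound 1 the strongest inhibitor shown and places a second group, after nitro, clearly short of it. Nothing available accounts for why chloro outdoes cyano and nitro here, or why tert-butyl gives the highest number.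

From the compounds shown here alone, whether fluoro, bromo, methyl or an amine at this same place would reach or pass chloro remains open. So does whether the order seen here would hold with these groups elsewhere on the aromatic ring, or with a change at the other end of the shared core.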